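Cytotoxicity notes: a labdane series and a planned analogue

The compounds below may be only part of what the source reports. "The series", "measured", "known", "first", "only" and "open" are said of these compounds alone.

Measured compounds:
compound 1 `CC(C)=CCc1cc(/C=C/C(=O)O)cc2c1OC(C)(C)C(O)C2`, 77.1 ug/mL
compound 2 `C=C1CC[C@@H]2[C@](C)(CCC[C@]2(C)C(=O)O)[C@H]1CC/C(C)=C/COC(C)=O`, 73.3 ug/mL

In a functional assay on cells (Mus musculus) for cytotoxicity, read by MTT assay, with a stated time of 24 h (on this read-out lower numbers stand for an effect already at smaller amounts and higher numbers for an effect only at larger amounts of compound), compound 1 gives 77.1 ug/mL. In this assay compound 2 gives 73.3 ug/mL, the lowest of the two numbers shown, with compound 1 as its nearest neighbour at a gap that lies within the usual scatter; the two values therefore cannot be ordered.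

Compound 3 `C=C[C@](C)(O)CC[C@H]1C(=C)CC[C@@H]2[C@]1(C)CCC[C@]2(C)C(=O)O` is not yet measured. It differs from compound 2 in one place: 1-hydroxy-1-methylprop-2-en-1-yl in place of 3-acetoxy-1-methylprop-1-en-1-yl on a saturated chain carbon, two bonds along the chain from a saturated ring carbon. For the measured compounds named here, no pair of measured compounds shares this change, so there is no measured step to draw on; the two values shown give no direction for it.

The step from compound 2 to compound 3 is expected to stay within the scatter: a 1.0-fold lower number from compound 2 to compound 3 (0.02 log units; within the scatter). Compound 3 is estimated at 70 ug/mL, in a range from 35 ug/mL to 140 ug/mL.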

Compound 3, concentration for half-maximal effect: > 100 ug/mL
Compound 3: a limit, no number; the forecaster's own chance of this, stated with the estimate: 10%; middle value at least 1.4-fold (0.15 log units) away from the limit.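

In this assay compound 3 gives only a limit, > 100 ug/mL, and not a number. For the compounds shown here, replacing 3-acetoxy-1-methylprop-1-en-1-yl with 1-hydroxy-1-methylprop-2-en-1-yl on a saturated chain carbon, two bonds along the chain from a saturated ring carbon, gives the first measured step at this place, an at least 1.3-fold higher number from compound 2 to compound 3 (0.13 log units; that floor lies within the scatter). The change brings no lower number, but a real rise is not established and the true size of the step stays unknown: the limit of > 100 ug/mL in this assay, at which 1 of the 3 values shown sits.

This single step removes the acetoxy group, moves the double bond and adds the hydroxyl together, and the compounds shown do not separate these changes. As far as these compounds go, how a primary alcohol or an amine on the same chain would read in this assay also remains open.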